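Removing a Methyl Group: Effect on Cell Toxicity

The source may report more compounds than this note shows. Statements on the series, on what has been measured and on what is new or still open speak of the compounds shown alone.

Compound 1, `Cc1cc(Oc2ccccc2OCCn2ccc(=O)[nH]c2=O)c2cc(C#N)[nH]c2c1`, was tested in an ADME assay on MT2 cells (Homo sapiens) for cytotoxicity, read by MTT assay (on this read-out higher numbers stand for lower toxicity in this test and lower numbers for higher toxicity in this test), where compound 1 gives 1200 nM. Among the measured compounds shown here, that is the lowest of the two numbers known here; compound 2, `O=c1ccn(CCOc2ccccc2Oc2cccc3ccccc23)c(=O)[nH]1`, gives 80000 nM, a far higher number, beyond the scatter. Compound 3, `N#Cc1cc2c(Oc3ccccc3OCCn3ccc(=O)[nH]c3=O)cccc2[nH]1`, has not yet been measured. It differs from compound 1 in one place: hydrogen in place of methyl on an aromatic carbon. For the measured compounds named here, no measured pair shows what this change does, so the step is expected to be small, within the scatter or a little upward. The value estimated for compound 3 is 1800 nM, between 600 nM and 6000 nM. This is expected to mean a step of a 1.5-fold higher number from compound 1 to compound 3 (0.18 log units; within the scatter).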

Compound 3, half-maximal cytotoxic concentration: 72000 nM
Compound 3: the middle estimate sits 40-fold (1.60 log units) below what was measured; measured number outside the range, above it.
By their numbers in this assay, from the lowest: compound 1; then compounds 3 and 2 (each within the scatter of the next).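

In this assay, hydrogen in place of methyl on this aromatic carbon gives a 60-fold higher number from compound 1 to compound 3 (1.78 log units; beyond the scatter) and so far lower toxicity in this test. The loss of one heavy atom is therefore enough to move the read-out well beyond the scatter, and the toxicity seen for compound 1 depends on the methyl at this position.

Going by these compounds, whether a larger group here, such as ethyl, or a different one, such as methoxy or chlorine, would keep that toxicity stays open. No measurement shown explains why this small change has so large an effect.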